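Moving a chlorine on the sulfonyl-bound ring

A few compounds are considered here, and "the series" means these few. Any claim that something is new, unique, unknown or untested is made for them only; others in the source may bear on it.

Compound 1, `CC1CCN(c2c(S(=O)(=O)c3cccc(Cl)c3)cnc3cc(Cl)ccc23)CC1`, gives 92% in an assay on isolated protein for displacement of a labelled ligand from metabotropic glutamate receptor 5 (Homo sapiens), with a stated time of 60 min, tested at 1 uM; a higher number here means more inhibition at the concentration tested (going by the name of the read-out), a lower number less inhibition.
Compound 2, `CC1CCN(c2c(S(=O)(=O)c3ccc(Cl)cc3)cnc3cc(Cl)ccc23)CC1`, gives 91% in this assay.
Compound 3, `CC1CCN(c2c(S(=O)(=O)c3ccc(Cl)cc3)cnc3ccc(F)cc23)CC1`, gives 80% in this assay.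

Compound 1 and compound 2 share one core and differ only in the ring on the sulfonyl sulfur: 3-chlorophenyl in place of 4-chlorophenyl on a sulfonyl sulfur. The change made a number 1 percentage points higher from compound 2 to compound 1 (within the scatter), so the two readings are indistinguishable here.

Compound 3 carries a different core; the difference between the two cores is not broken down here. Its reading is the lowest of the three, and both compound 1 and compound 2 stand beyond the scatter above it.

Compound 4, `CC1CCN(c2c(S(=O)(=O)c3cccc(Cl)c3)cnc3ccc(F)cc23)CC1`, has not yet been measured. It stands to compound 3 as compound 1 stands to compound 2: 3-chlorophenyl in place of 4-chlorophenyl on a sulfonyl sulfur. The place of the change is the same in both pairs. Because the earlier change gave a number 1 percentage points higher from compound 2 to compound 1 (within the scatter), the step from compound 3 is expected to be small as well, about a number 1 percentage points higher from compound 3 to compound 4 (within the scatter). Compound 4 is therefore estimated at 81%, with a likely range from 70% to 90%.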

Compound 4, a percentage reported as inhibition, at one concentration (the size of the read-out at that concentration, not a potency): 92%
Estimate against measurement, compound 4: 11 percentage points below, and the stated range ends below it.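

On the second core, moving to the 3-chlorophenyl group gives a clear step in this assay, with a number 12 percentage points higher from compound 3 to compound 4 (beyond the scatter). Set beside the first pair, however, the two steps cannot be told apart, even though only one of them lies beyond the scatter on its own: the same change on two cores in this assay, a number 1 percentage points higher (within the scatter) from compound 2 to compound 1 and a number 12 percentage points higher (beyond the scatter) from compound 3 to compound 4, 11 percentage points apart, within the scatter of two such steps. Neither pair shows a fall beyond the scatter with this change, but two pairs do not show that the size of the step depends on the core, nor that it is the same on both, and they give no rule for any other core.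

The compounds shown leave open how the sulfonyl-bound ring behaves when the chlorine is replaced by another group, such as a methoxy group or a nitrile. They also leave open how these compounds rank by potency, since a percentage read at one concentration is not a potency.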